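Carbamoyl in Place of Sulfamoyl: an Expected Clearance

The source may report more compounds than this note shows. Statements on the series, on what has been measured and on what is new or still open speak of the compounds shown alone.

Compound 1, `COc1ccc(-c2cc(-c3cccc(S(C)(=O)=O)c3)cnc2N)cn1`, 7.6 mL.min-1.g-1 in an in vitro ADME assay on microsomes from liver (Homo sapiens) for metabolic stability; a lower number here means slower removal, a higher number faster removal of the compound.
Compound 2, `COc1ccc(-c2cc(-c3ccc(S(N)(=O)=O)cc3)cnc2N)cn1`, < 7 mL.min-1.g-1 in this assay.
Compound 3, `COc1ccc(-c2cc(-c3ccc4nccn4c3)cnc2N)cn1`, 12 mL.min-1.g-1 in this assay.

Of the three measured compounds, compound 2 is the one for which this assay reports only a limit: its value of < 7 mL.min-1.g-1 is a limit of the assay and not a number. That limit, (the limit of < 7 mL.min-1.g-1 in this assay, at which 1 of the 3 values shown sits), places compound 2 at the edge of what the assay resolves, while compound 1 and compound 3 each give a measured number.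

Compound 4 is `COc1ccc(-c2cc(-c3ccc(C(N)=O)cc3)cnc2N)cn1`. It differs from compound 2 in one place: carbamoyl in place of sulfamoyl on an aromatic carbon, para to a large group. Going by the values given here, no measured pair shows this particular change, so the size of the step can only be anticipated.

The expectation is that this step from compound 2 to compound 4 stays within the usual scatter, an at least 1.1-fold higher number from compound 2 to compound 4 (0.05 log units; that floor lies within the scatter), with no clear direction. Compound 4 is therefore expected to give about 8 mL.min-1.g-1 in this assay, between 5 mL.min-1.g-1 and 16 mL.min-1.g-1, with a fair chance that the assay again reports only a limit.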

Compound 4, intrinsic clearance in microsomes: < 7 mL.min-1.g-1
Compound 4: only a limit was reported; the forecaster's own chance of this, stated with the estimate: 35%; middle value at least 1.1-fold (0.05 log units) away from the limit.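

In this assay compound 4 gives < 7 mL.min-1.g-1 as a limit of the assay and not a number. Going by these compounds alone, compound 2 likewise gives < 7 mL.min-1.g-1 as a limit, and no step between compound 2 and compound 4 can be read from these two results. The compounds shown leave open how far apart compound 2 and compound 4 actually lie.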